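From Trifluoromethyl to Acetamido: An Expected Potency Shift

The source may hold more compounds than are shown below. What is called first, only, known or untested is meant among the compounds shown, and "the series" means these compounds.

Among the compounds with values here, in a functional assay on BJAB cells (Homo sapiens) for antiproliferative activity, with a stated time of 4 days (on this read-out lower numbers stand for an effect already at smaller amounts and higher numbers for an effect only at larger amounts of compound), compound 2 (`Cc1nn(-c2nc(-c3ccc(Cl)c(Cl)c3)c(SC(C)C)s2)c(C(=O)O)c1-c1ccc(C(F)(F)F)cc1`) gives 3500 nM, the lower of the two numbers known so far; compound 1 (`COc1ccccc1-c1c(C)nn(-c2nc(-c3ccc(Cl)c(Cl)c3)c(SC(C)C)s2)c1C(=O)O`) gives 14700 nM, and a 4.2-fold lower number from compound 1 to compound 2 (0.62 log units; beyond the scatter) is the only measured step. Compound 3 (`CC(=O)Nc1ccc(-c2c(C)nn(-c3nc(-c4ccc(Cl)c(Cl)c4)c(SC(C)C)s3)c2C(=O)O)cc1`) differs from compound 2 by acetamido in place of trifluoromethyl on an aromatic carbon. Within the data shown here, that earlier step shows only that the group on this ring can move the number substantially, not in which direction a donor-bearing replacement would act. Compound 3 is therefore expected near 7000 nM (range 2000 nM to 25000 nM). That estimate means a 2.0-fold higher number from compound 2 to compound 3 (0.30 log units; within the scatter), expected to run toward a higher number.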

Compound 3, half-maximal effective concentration: 139000 nM
For compound 3 the middle estimate is 20-fold (1.30 log units) below the measured one, outside the stated range (above it).
By their numbers in this assay, from the lowest: compound 2; then compound 1; then compound 3.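

In this assay, within the data shown here, the change to acetamido on this aromatic carbon brings a 40-fold higher number from compound 2 to compound 3 (1.60 log units; beyond the scatter) and so supplies what the earlier compounds could not: a measured direction for this replacement, upward and by a large step. The 4-acetamidophenyl group also compares with 2-methoxyphenyl through a 9.5-fold higher number from compound 1 to compound 3 (0.98 log units; beyond the scatter) and leaves compound 3 with the highest number of the three. No measurement given here accounts for this rise. From the compounds shown here alone, whether the amide hydrogen or the carbonyl matters stays open, and an amine or a longer acyl chain at this place could begin to separate the two.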